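Swapping the aryl substituent to a sulfonamide

The compounds below may be only part of what the source reports. "The series", "measured", "known", "first", "only" and "open" are said of these compounds alone.

Three compounds share one core and differ only in the group on the outer six-membered ring. Compound 1 `CCCS(=O)(=O)Nc1ccc(F)c(C(=O)c2n[nH]c3ncc(-c4ccc(N)cc4)cc23)c1F` gives 0.1% in an assay for binding affinity to dual specificity mitogen-activated protein kinase kinase 4 (Homo sapiens), read by KINOMEscan, tested at 100 nM; on this read-out higher numbers stand for a weaker effect at the one concentration tested and lower numbers for a stronger effect. Compound 2 `CCCS(=O)(=O)Nc1ccc(F)c(C(=O)c2n[nH]c3ncc(-c4ccc(N(C)C)cc4)cc23)c1F` gives 2.5% in this assay, and compound 3 `CCCS(=O)(=O)Nc1ccc(F)c(C(=O)c2n[nH]c3ncc(-c4ccc([N+](=O)[O-])cc4)cc23)c1F` gives 4.2%. Compound 2 sits second highest of the three numbers, but its neighbours lie within the scatter: a number 2.4 percentage points higher from compound 1 to compound 2 (within the scatter) and a number 1.7 percentage points higher from compound 2 to compound 3 (within the scatter). The third measured step, a number 4.1 percentage points higher from compound 1 to compound 3 (within the scatter), is also within the scatter, so nothing here separates amino, dimethylamino and nitro.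

Compound 4 `CCCS(=O)(=O)Nc1ccc(F)c(C(=O)c2n[nH]c3ncc(-c4ccc(NS(C)(=O)=O)cc4)cc23)c1F` is not yet measured. Its change from compound 2 is methanesulfonamido in place of dimethylamino on an aromatic carbon, placed on an aromatic carbon of a six-membered aromatic ring of carbon only, para to a large group. Among the compounds with values here, no measured step involves methanesulfonamido, so only the observation that three different groups at this position all leave very strong binding bears on it. A step no larger than the scatter is therefore expected, a number 1.5 percentage points higher from compound 2 to compound 4 (within the scatter). Compound 4 is estimated at 4%, with a range from 0.5% to 25%.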

Compound 4, a percentage reported as activity, at one concentration (the size of the read-out at that concentration, not a potency): 0.85%
Estimate against measurement, compound 4: 3.2 percentage points above, within the range that was stated.
By their numbers in this assay, from the lowest: compounds 1, 4, 2 and 3 (each within the scatter of the next).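

In this assay, methanesulfonamido cannot be told apart from any of the three groups measured before it (a number 1.7 percentage points lower from compound 2 to compound 4 (within the scatter); a number 3.4 percentage points lower from compound 3 to compound 4 (within the scatter); a number 0.8 percentage points higher from compound 1 to compound 4 (within the scatter)). The position therefore also tolerates a group with five heavy atoms and a hydrogen-bond donor, whereas dimethylamino has three heavy atoms and no donor, and the number stays within the scatter of the others. Nothing measured here offers a reason why these groups read alike.

On these data alone, what remains open is whether any group at this position would move the number beyond the scatter, for example a carboxylic acid or a longer chain on the sulfonyl such as propylsulfonamido. The four compounds shown also leave open how these groups would rank, as their numbers do not separate them.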